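This account rests on a few compounds, and the source may have more. Where it says the series, first, only, none or still open, it means among the compounds named here.

The measured compounds in a functional assay on UACC-62 cells (Homo sapiens) for inhibition, read by sulforhodamine B assay, with a stated time of 48 h, tested at 1 uM; on this read-out higher numbers stand for a weaker effect at the one concentration tested and lower numbers for a stronger effect:
Compound 1, `COc1cc(Cl)cc(-c2nn(-c3cccc(NC(=O)Nc4ccc(Cl)c(C(F)(F)F)c4)c3)cc2-c2ccncc2)c1`, gives 82%.
Compound 2, `COc1cc(Cl)cc(-c2nn(-c3cccc(NC(=O)Nc4ccc(Cl)c(Cl)c4)c3)cc2-c2ccncc2)c1`, gives 75%.
Compound 3, `COc1cc(Cl)cc(-c2nn(-c3cccc(NC(=O)Nc4cccc(C(F)(F)F)c4)c3)cc2-c2ccncc2)c1`, gives 70%.

Of the three numbers, that of compound 3 is the lowest, though its nearest neighbour is compound 2 with a number 5 percentage points lower from compound 2 to compound 3 (within the scatter), a step within the scatter; further off is compound 1 with a number 12 percentage points lower from compound 1 to compound 3 (beyond the scatter), a modest step beyond the scatter. Compound 4, `COc1cc(Cl)cc(-c2nn(-c3cccc(NC(=O)c4cccc(C(F)(F)F)c4)c3)cc2-c2ccncc2)c1`, has not been measured in this assay. It differs from compound 3 in one place: 3-(trifluoromethyl)phenyl in place of (3-(trifluoromethyl)phenyl)amino on a carbonyl carbon. Among the measured compounds shown here, none of the measured steps touches this place: a number 7 percentage points lower from compound 1 to compound 2 (within the scatter), a number 12 percentage points lower from compound 1 to compound 3 (beyond the scatter) and a number 5 percentage points lower from compound 2 to compound 3 (within the scatter) all concern changes elsewhere in the molecule and leave the carbonyl carbon and its neighbours untouched. The data therefore give no ground for expecting a step in this assay beyond the scatter in either direction, and the estimate for compound 4 is carried over from compound 3 with a wide range. Compound 4 is expected to give 72%, between 50% and 92%. This corresponds to an expected step of a number 2 percentage points higher from compound 3 to compound 4 (within the scatter).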

Compound 4, a percentage reported as activity, at one concentration (the size of the read-out at that concentration, not a potency): 56%
Estimate against measurement, compound 4: 16 percentage points above; measured number inside the range.
By their numbers in this assay, from the lowest: compound 4; then compounds 3, 2 and 1 (each within the scatter of the next, the first and the last beyond it).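

In this assay, the carbonyl carbon turns out to be a place where the read-out can move: exchanging (3-(trifluoromethyl)phenyl)amino for 3-(trifluoromethyl)phenyl, which takes away one nitrogen and one hydrogen-bond donor, gives a number 14 percentage points lower from compound 3 to compound 4 (beyond the scatter). Set against the other two amino-linked aryl groups, the same kind of exchange gives a number 19 percentage points lower from compound 2 to compound 4 (beyond the scatter) and a number 26 percentage points lower from compound 1 to compound 4 (beyond the scatter), so compound 4 shows the strongest effect of the four at the one concentration tested. Nothing available here accounts for this shift.

The compounds shown do not separate the loss of the nitrogen from the loss of its hydrogen, a question that a methylene group or a methylated amino nitrogen at that place would address. Going by these compounds, it also remains open whether the 3,4-dichlorophenyl or 4-chloro-3-(trifluoromethyl)phenyl group, attached directly to the carbonyl carbon, would follow compound 4.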